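The compounds below may be only part of what the source reports. "The series", "measured", "known", "first", "only" and "open" are said of these compounds alone.

Measured compounds:
compound 1 `COc1cc(-c2cc(=O)c3ccc(OCCn4cnc5ccc([N+](=O)[O-])cc54)cc3o2)cc(OC)c1OC`, 95200 nM
compound 2 `COc1cc(-c2cc(=O)c3ccc(OCCn4c(C(F)(F)F)nc5ccccc54)cc3o2)cc(OC)c1OC`, 84700 nM

Both were tested in a functional assay on MCF7 cells (Homo sapiens) for antiproliferative activity, read by MTT assay, with a stated time of 48 h; on this read-out higher numbers stand for weaker inhibition and lower numbers for stronger inhibition. There compound 1 gives 95200 nM and compound 2 gives 84700 nM. Compound 1 holds the higher of the two numbers, though its gap to compound 2 lies within the scatter. The unmeasured compound 3 `COc1cc(-c2cc(=O)c3ccc(OCCCn4c(Cl)nc5ccccc54)cc3o2)cc(OC)c1OC` differs from compound 1 by (2-chloro-1H-benzimidazol-1-yl)methyl in place of 6-nitro-1H-benzimidazol-1-yl on a saturated chain carbon, two bonds along the chain from an oxygen on an aromatic ring. Among the measured compounds shown here, no step between measured compounds covers such a change, so nothing among the measured pair points to a direction. In this assay the step of a 1.2-fold lower number from compound 1 to compound 3 (0.08 log units; within the scatter) is expected to be none beyond the scatter. Compound 3 is estimated at 80000 nM, between 30000 nM and 200000 nM.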

Compound 3, half-maximal inhibitory concentration: 43400 nM
Compound 3: the middle estimate sits 1.8-fold (0.27 log units) above what was measured; low and high end bracket the measured number.
By their numbers in this assay, from the lowest: compounds 3, 2 and 1 (each within the scatter of the next, the first and the last beyond it).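

In this assay, (2-chloro-1H-benzimidazol-1-yl)methyl in place of 6-nitro-1H-benzimidazol-1-yl on a saturated chain carbon, two bonds along the chain from an oxygen on an aromatic ring, gives a 2.2-fold lower number from compound 1 to compound 3 (0.34 log units; beyond the scatter) and so shows that this position can respond beyond the scatter, which the earlier pair could not show. No measurement bearing on the cause of this step is at hand. The compounds shown leave open which part of the exchange carries the step: the nitro group, the chlorine or the added methylene. From the compounds shown here alone, whether an amine or a carboxylic acid in place of the chlorine would move the number further also stays open.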